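From Hydroxymethyl to Nitro on a Shared Core

This account rests on a few compounds, and the source may have more. Where it says the series, first, only, none or still open, it means among the compounds named here.

The measured compounds:
compound 1, `O=Cc1cn([C@H]2C[C@H](O)[C@@H](OP(=O)(O)O)O2)c(=O)[nH]c1=O`: 16200000 nM in an assay on L1210 cells for inhibition of Thymidylate synthase (Mus musculus); a lower number here means a stronger inhibitor, a higher number a weaker inhibitor
compound 2, `O=c1[nH]c(=O)n([C@H]2C[C@H](O)[C@@H](OP(=O)(O)O)O2)cc1CO`: 269000000 nM in this assay

Compound 2 stands at the highest of the two numbers in this assay; its nearest neighbour is compound 1, and the step of a 17-fold higher number from compound 1 to compound 2 (1.22 log units; beyond the scatter) lies beyond the scatter. Compound 3, `O=c1[nH]c(=O)n([C@H]2C[C@H](O)[C@@H](OP(=O)(O)O)O2)cc1[N+](=O)[O-]`, has not yet been measured. It differs from compound 2 by nitro in place of hydroxymethyl on an aromatic carbon. Within the data shown here, no measured step involves a nitro group, so nothing covers this change directly. Among the measured compounds shown here, the only step known concerns the same aromatic carbon: a 17-fold higher number from compound 1 to compound 2 (1.22 log units; beyond the scatter) shows that exchanging one small group for another there moves the number strongly. By analogy, one would expect the step to compound 3 to be large as well, and since compound 2 holds the highest number, the more likely direction is downward. The number for compound 3 in this assay is therefore estimated at 10000000 nM, within a range from 300000 nM to 300000000 nM, a step of a 27-fold lower number from compound 2 to compound 3 (1.43 log units; beyond the scatter).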

Compound 3, inhibition constant: 2570000 nM
For compound 3 the middle estimate is 3.9-fold (0.59 log units) above the measured one; low and high end bracket the measured number.
By their numbers in this assay, from the lowest: compound 3; then compound 1; then compound 2.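

On this aromatic carbon, exchanging hydroxymethyl for nitro gives the largest change among the three compounds in this assay (a 100-fold lower number from compound 2 to compound 3 (2.02 log units; beyond the scatter)), so the position responds even more strongly than the earlier exchange of formyl for hydroxymethyl had suggested. The comparison with the formyl compound adds a second, smaller move in the same direction (a 6.3-fold lower number from compound 1 to compound 3 (0.80 log units; beyond the scatter)), which makes compound 3 the strongest inhibitor of the three, with formyl in the middle and hydroxymethyl the weakest, each separated from the others by more than the scatter. The numbers thus rank three small groups at one site on the shared core, but nothing available bears on why they fall in this order.

Among these compounds, with only three groups at this carbon, the ranking cannot be extended to others, and it remains open where an amine, a carboxylic acid, a nitrile or a longer chain such as ethyl would fall in the same assay. On these data alone, it is equally open whether the same order would hold on a different core or against the enzyme from another species.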